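The source may report more compounds than this note shows. Statements on the series, on what has been measured and on what is new or still open speak of the compounds shown alone.

In an ADME assay on BaF3 cells (Mus musculus) for antiproliferative activity, read by CCK-8 assay, with a stated time of 72 h (on this read-out higher numbers stand for weaker inhibition of growth and lower numbers for stronger inhibition of growth), compound 1 `CN1CCN(Cc2ccc(NC(=O)CCSc3ccc4c(/C=C/c5ccccn5)n[nH]c4c3)cc2C(F)(F)F)CC1` gives 2480 nM. This lies within the scatter of compound 2 `CN(C)CCN(C)Cc1ccc(NC(=O)CCSc2ccc3c(/C=C/c4ccccn4)n[nH]c3c2)cc1C(F)(F)F` at 1850 nM and of compound 3 `Cc1cn(Cc2ccc(NC(=O)CCSc3ccc4c(/C=C/c5ccccn5)n[nH]c4c3)cc2C(F)(F)F)cn1` at 1990 nM. Compound 4 `CN1CCN(Cc2ccc(NC(=O)CCSc3ccc4c(-c5cccnc5)n[nH]c4c3)cc2C(F)(F)F)CC1` carries pyridin-3-yl in place of 2-(pyridin-2-yl)ethenyl on an aromatic carbon. The measured steps, a 1.3-fold lower number from compound 1 to compound 2 (0.13 log units; within the scatter) and a 1.2-fold lower number from compound 1 to compound 3 (0.10 log units; within the scatter), lie within the scatter, but both concern a saturated chain carbon, so neither tests this change directly. Going by the values given here, with no measured step at this aromatic carbon, no shift beyond the scatter is expected in this assay, though with wide uncertainty. The expected change is a 1.2-fold higher number from compound 1 to compound 4 (0.08 log units; within the scatter). For compound 4 the estimated value is 3000 nM, with an expected range of 1000 nM to 9000 nM.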

Compound 4, concentration for 50% growth inhibition: 2650 nM
Estimate against measurement, compound 4: 1.1-fold (0.05 log units) above; measured number inside the range.
By their numbers in this assay, from the lowest: compounds 2, 3, 1 and 4 (each within the scatter of the next).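

In this assay, going by these compounds alone, pyridin-3-yl in place of 2-(pyridin-2-yl)ethenyl on this aromatic carbon gives a 1.1-fold higher number from compound 1 to compound 4 (0.03 log units; within the scatter), the first measured step at this position rather than at the saturated chain carbon. Losing the double bond outside aromatic rings therefore leaves the number within the scatter here. No evidence is available that explains this result. The compounds shown leave open whether a different group on this carbon, such as an amine, a carboxylic acid or a phenyl ring, would shift the number beyond the scatter. They also leave open whether 4-methyl-1H-imidazol-1-yl would behave the same alongside pyridin-3-yl.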